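The compounds below may be only part of what the source reports. "The series", "measured", "known", "first", "only" and "open" are said of these compounds alone.

Working notes on the series. The shared core is seen in compound 1 `COc1ccc2c(-c3ccccc3)nn(-c3nc(C(=O)O)cs3)c2c1`, which in an assay on isolated protein for antagonist activity at prostaglandin E2 receptor EP1 subtype (Homo sapiens), read by reporter gene assay (a higher number here means a weaker inhibitor, a lower number a stronger inhibitor), gives 1.1 nM. Within the data shown here, compound 2 `O=C(O)c1csc(-n2nc(-c3cccc(F)c3)c3ccccc32)n1` gives 20 nM in this assay, the highest of the two numbers so far; its nearest neighbour on the numbers is compound 1, and the gap between the two lies beyond the scatter. Compound 3 `COc1ccc(-c2nn(-c3nc(C(=O)O)cs3)c3ccccc23)cc1` has not been measured. Compound 3 differs from compound 2 in one place: 4-methoxyphenyl in place of 3-fluorophenyl on an aromatic carbon. Among the measured compounds shown here, no pair of measured compounds that differ in only one place is available, so the size of this step cannot be read from any measured step. Compound 1 carries a methoxy group on the fused ring system and a plain phenyl group, which is a different change and gives no direct guide. The expectation for compound 3 in this assay is a modest step towards a lower number, a 2.5-fold lower number from compound 2 to compound 3 (0.40 log units; beyond the scatter), with wide uncertainty. The estimate for compound 3 is 8 nM, expected to lie between 2 nM and 40 nM.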

Compound 3, half-maximal inhibitory concentration: 4 nM
Estimate against measurement, compound 3: 2.0-fold (0.30 log units) above; low and high end bracket the measured number.
By their numbers in this assay, from the lowest: compound 1; then compound 3; then compound 2.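

In this assay, 4-methoxyphenyl in place of 3-fluorophenyl on the aromatic carbon two ring bonds from the ring atom that bears the 4-carboxy-1,3-thiazol-2-yl group gives a 5.0-fold lower number from compound 2 to compound 3 (0.70 log units; beyond the scatter) and provides the only single-place step shown for this series. The position is therefore not indifferent to the group it carries, as this one change moves the number beyond the scatter. No measurement at hand bears on why the step occurs.

The compounds shown leave open whether the step follows the entry of the methoxy group, the loss of fluorine, or the different place of the group on the phenyl ring. Also open, as far as these compounds go, is how an ethoxy group or an amine on that phenyl ring would read in this assay against the methoxy group of compound 3.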